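Series notes: aryl exchange on the five-membered core

This account rests on a few compounds, and the source may have more. Where it says the series, first, only, none or still open, it means among the compounds named here.

Compound 2 `COc1cccc(-c2ncnn2-c2cc(OC)c(OC)c(OC)c2)c1` stands at the edge of what a functional assay on HL-60 cells (Homo sapiens) for antiproliferative activity, read by MTT assay, with a stated time of 72 h (a lower number here means a stronger inhibitor, a higher number a weaker inhibitor), can report: compound 2 gives > 10000 nM, which is a limit of the assay and not a number. Compound 1 `COc1cc(-c2ncnn2-c2cccc(F)c2)cc(OC)c1OC` likewise returns only a limit, > 10000 nM. Compound 3 `CCOc1cccc(-c2ncnn2-c2cc(OC)c(OC)c(OC)c2)c1` also returns a limit, > 10000 nM. Within the data shown here, the single measured step, a step that the two limits leave unreadable from compound 2 to compound 3, is unsized because the limit of > 10000 nM in this assay, at which 3 of the 3 values shown sit, covers all three results. Compound 4 `COc1cc(-n2ncnc2-c2ccc(SC)cc2)cc(OC)c1OC` is the unmeasured member and differs from compound 2 by 4-(methylsulfanyl)phenyl in place of 3-methoxyphenyl on an aromatic carbon. Among the measured compounds shown here, no measured step touches this exchange; the only bearing is that every value so far sits at the limit. The step from compound 2 to compound 4 is expected at an at least 1.2-fold lower number from compound 2 to compound 4 (0.09 log units; that floor lies within the scatter), most likely without a readable gain. Compound 4 is accordingly estimated at 8000 nM, within 800 nM to 30000 nM.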

Compound 4, half-maximal inhibitory concentration: 500 nM
Estimate against measurement, compound 4: 16-fold (1.20 log units) above; measured number below the stated range.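

In this assay, 4-(methylsulfanyl)phenyl in place of 3-methoxyphenyl on this aromatic carbon gives an at least 20-fold lower number from compound 2 to compound 4 (1.30 log units; beyond the scatter). Among these compounds, the earlier steps cannot be read, so this is the first sign that the group at this position can move the read-out. The size is a floor and not a full measure, because compound 2 gives only a limit: the limit of > 10000 nM in this assay, at which 3 of the 4 values shown sit.

The compounds shown do not separate the exchange of oxygen for sulfur from the shift of the group on the phenyl ring, since neither 4-methoxyphenyl nor 3-(methylsulfanyl)phenyl stands among them. From the compounds shown here alone, whether a 4-aminophenyl group at this position would give a similar step also stays open.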